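This account rests on a few compounds, and the source may have more. Where it says the series, first, only, none or still open, it means among the compounds named here.

Compound 1 `COc1cccc(OC)c1N1C(=O)CSC1c1cccc(C(=O)NCCCCc2ccccc2)c1` gives the higher of the two measured numbers: in a functional assay on HOS-TE85 cells (Homo sapiens) for inhibition, read by CCK-8 assay, with a stated time of 72 h, tested at 1 uM (a lower number here means less inhibition, a higher number more inhibition at the concentration tested (going by the name of the read-out)), compound 1 gives 95%. Compound 2 `COc1c(F)cccc1N1C(=O)CSC1c1cccc(C(=O)NCCCCc2ccccc2)c1`, which carries 3-fluoro-2-methoxyphenyl in place of 2,6-dimethoxyphenyl on an amide-type nitrogen in a ring, gives 12% in this assay, and the step is a number 83 percentage points lower from compound 1 to compound 2 (beyond the scatter). For the measured compounds named here, compound 2 therefore stands lowest of the two numbers known, with compound 1 the nearest and far above it.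

Compound 3 `COc1ccc(N2C(=O)CSC2c2cccc(C(=O)NCCCCc3ccccc3)c2)c(OC)c1` differs from compound 2 in one place: 2,4-dimethoxyphenyl in place of 3-fluoro-2-methoxyphenyl on an amide-type nitrogen in a ring. Going by the values given here, only one measured step bears on this change, and it runs the other way, because a number 83 percentage points lower from compound 1 to compound 2 (beyond the scatter) shows that removing a methoxy group for a fluorine cost most of the inhibition. Restoring a second methoxy group, though at a different position of the ring, is expected to recover much of it. Compound 3 is expected to give 65%, between 25% and 95%. The expected step is a number 53 percentage points higher from compound 2 to compound 3 (beyond the scatter).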

Compound 3, a percentage reported as inhibition, at one concentration (the size of the read-out at that concentration, not a potency): 58%
Compound 3: the middle estimate sits 7 percentage points above what was measured; the measured number falls inside the stated range.
By their numbers in this assay, from the lowest: compound 2; then compound 3; then compound 1.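

In this assay, the 2,4-dimethoxyphenyl group on the amide-type nitrogen recovers much of the inhibition missing with the 3-fluoro-2-methoxyphenyl group, with a number 46 percentage points higher from compound 2 to compound 3 (beyond the scatter). The recovery is only partial, with a number 37 percentage points lower from compound 1 to compound 3 (beyond the scatter), so having two methoxy groups on this phenyl ring does not by itself set the result: the 2,6-dimethoxyphenyl and 2,4-dimethoxyphenyl groups carry the same two substituents in different placements, and their numbers still differ beyond the scatter. Nothing available here accounts for these differences.

The compounds shown leave open how much inhibition a single methoxy group on the phenyl ring would keep, as the 2-methoxyphenyl group is not among them. They also leave open whether a 2,6-diethoxyphenyl or 2,6-difluorophenyl group would match the 2,6-dimethoxyphenyl group.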